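A few compounds are considered here, and "the series" means these few. Any claim that something is new, unique, unknown or untested is made for them only; others in the source may bear on it.

In a functional assay on the whole organism with Mus musculus as the target (on this read-out lower numbers stand for an effect already at smaller amounts and higher numbers for an effect only at larger amounts of compound), compound 1 `CC1(C)OC(C)(C)c2nc(-c3ccccc3)nnc21` gives 167 mg/kg. Compound 2 `CC1(C)OC(C)(C)c2nc(-c3cccc([N+](=O)[O-])c3)nnc21` carries the change nitro in place of hydrogen on an aromatic carbon and gives 68.8 mg/kg in this assay; the step of a 2.4-fold lower number from compound 1 to compound 2 (0.39 log units; beyond the scatter) is modest but beyond the scatter. Compound 3 `CC1(C)C/C(=N\Nc2ccccc2)C(C)(C)O1` rests on a different core; the difference between the two cores is not broken down here. In this assay compound 3 gives 163 mg/kg, which lies within the scatter of the number for compound 1 and is higher than that for compound 2 by a margin beyond the scatter.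

Compound 4 `CC1(C)C/C(=N\Nc2ccccc2[N+](=O)[O-])C(C)(C)O1`, not yet measured, differs from compound 3 by nitro in place of hydrogen on an aromatic carbon. This is the same kind of change as that from compound 1 to compound 2, but the nitro group stands ortho to a large group here, whereas in compound 2 it stands meta to a large group. Going by the values given here, on the strength of the single step of a 2.4-fold lower number from compound 1 to compound 2 (0.39 log units; beyond the scatter), compound 4 is expected to show a step of a 2.0-fold lower number from compound 3 to compound 4 (0.31 log units; beyond the scatter) in this assay, and its number in this assay is estimated at 80 mg/kg, between 45 mg/kg and 165 mg/kg.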

Compound 4, dose for half-maximal effect: 1000 mg/kg
Beside the measured number, compound 4's estimate is 13-fold (1.10 log units) below it, outside the stated range (above it).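

In this assay, nitro in place of hydrogen on an aromatic carbon gives a 6.1-fold higher number from compound 3 to compound 4 (0.79 log units; beyond the scatter), so the change does not carry over with the same direction from the core of compound 1 to the core of compound 3. The two steps point opposite ways and differ by more than the scatter allows: the same change on two cores in this assay, a 2.4-fold lower number (0.39 log units; beyond the scatter) from compound 1 to compound 2 and a 6.1-fold higher number (0.79 log units; beyond the scatter) from compound 3 to compound 4, 15-fold (1.17 log units) apart, beyond the scatter of two such steps. This does not show that the core alone sets the outcome, since the nitro in compound 4 stands ortho to a large group while the nitro in compound 2 stands elsewhere on its ring, and this one pair of steps cannot separate the place from the core.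

The compounds shown leave open how nitro ortho to a large group would act on the core of compound 1, and how nitro placed as in compound 2 would act on the core of compound 3. They also leave open what another group in the same place, such as an amine or a carboxylic acid, would do to the dose on either core.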